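Extending the Amine Substituent from Propyl to Cyclopentylmethyl

The compounds below may be only part of what the source reports. "The series", "measured", "known", "first", "only" and "open" are said of these compounds alone.

Compound 1 `CCCN(Cc1ccc(OCCN2C(=O)CCC2=O)c(C)c1)C(CC(=O)O)c1ccc(Cl)cc1` is examined in an ADME assay on Caco-2 cells (Homo sapiens) for permeability, read by LC-MS, with a stated time of 2 h (a lower number here means that the compound crosses the layer more slowly, a higher number that the compound crosses the layer faster), where compound 1 gives 10.2 nm/s. Among the three measured compounds it stands second highest: compound 3 `CCCCN(Cc1ccc(OCCN2C(=O)CCC2=O)c(C)c1)C(CC(=O)O)c1ccc(Cl)cc1` gives 13.5 nm/s, a change of a 1.3-fold higher number from compound 1 to compound 3 (0.12 log units; within the scatter), while compound 2 `CCN(Cc1ccc(OCCN2C(=O)CCC2=O)c(C)c1)C(CC(=O)O)c1ccc(Cl)cc1` gives 3.9 nm/s, a change of a 2.6-fold lower number from compound 1 to compound 2 (0.42 log units; beyond the scatter). From compound 2 to compound 3 the step is a 3.5-fold higher number from compound 2 to compound 3 (0.54 log units; beyond the scatter). Compound 4 `Cc1cc(CN(CC2CCCC2)C(CC(=O)O)c2ccc(Cl)cc2)ccc1OCCN1C(=O)CCC1=O` differs from compound 1 by cyclopentyl in place of ethyl on a saturated chain carbon bound to an amine nitrogen; cut one bond further out, the change reads propyl to cyclopentylmethyl. The measured steps all add or remove chain carbons near the same amine nitrogen, and the two steps beyond the scatter both run toward higher numbers with more carbons. Compound 4 is therefore expected to show a step of a 1.7-fold higher number from compound 1 to compound 4 (0.22 log units; within the scatter), modest and upward. Compound 4 is estimated at 17 nm/s, between 8 nm/s and 35 nm/s.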

Compound 4, apparent permeability: 28.9 nm/s
Compound 4: the middle estimate sits 1.7-fold (0.23 log units) below what was measured; low and high end bracket the measured number.
By their numbers in this assay, from the lowest: compound 2; then compounds 1 and 3 (each within the scatter of the next); then compound 4.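

At this amine nitrogen the number keeps climbing past the point where compound 1 and compound 3 lay within the scatter of each other: the cyclopentylmethyl group gives (a 2.8-fold higher number from compound 1 to compound 4 (0.45 log units; beyond the scatter)) and (a 2.1-fold higher number from compound 3 to compound 4 (0.33 log units; beyond the scatter)). Going by these compounds alone, the whole span reaches (a 7.4-fold higher number from compound 2 to compound 4 (0.87 log units; beyond the scatter)), and among the four compounds only the pair compound 1 and compound 3 fails to separate as carbon is added. Nothing measured here explains the rise.

From the compounds shown here alone, whether the ring or simply the added carbons carries this rise stays open. An open hexyl chain, a cyclohexylmethyl group or a ring holding an ether oxygen would tell these apart.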